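The compounds below may be only part of what the source reports. "The series", "measured", "known", "first", "only" and "open" are said of these compounds alone.

Compound 1 `Cc1ccc(COc2nc3ccccc3s2)cc1` was tested in a functional assay on the whole organism with Mus musculus as the target, with a stated time of 1 h, at a dose of 100 mg/kg by the intraperitoneal route (a lower number here means less inhibition, a higher number more inhibition at the dose given (going by the name of the read-out)), and gave 1.95%, the lowest of the three numbers recorded. Compound 2 `COc1cc(COc2nc3ccccc3s2)cc(OC)c1` gave 44.4% in this assay, and compound 3 `Clc1ccc(OCCOc2nc3ccccc3s2)c(Cl)c1` gave 85.4%; both stand beyond the scatter above compound 1. Compound 4 `COc1ccc(COc2nc3ccccc3s2)cc1` has not been measured yet. It differs from compound 1 by a single change: methoxy in place of methyl on an aromatic carbon. For the measured compounds named here, no step between two measured compounds isolates this change, so the expectation rests on the spread of the three measured numbers alone. Because compound 2, which also carries methoxy groups, gave 44.4%, a modest rise is expected, with the step from compound 1 to compound 4 estimated at a number 16.1 percentage points higher from compound 1 to compound 4 (beyond the scatter). Compound 4 is expected to give 18%, within a range from 0% to 45%.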

Compound 4, a percentage reported as inhibition, in the whole organism at one dose (the size of the read-out at that dose, not a potency): 2.43%
Estimate against measurement, compound 4: 15.6 percentage points above; the range from low to high includes it.
By their numbers in this assay, from the lowest: compounds 1 and 4 (each within the scatter of the next); then compound 2; then compound 3.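

For the compounds shown here, measured directly for the first time, methoxy in place of methyl on this aromatic carbon, para to a large group, gives in this assay a number 0.5 percentage points higher from compound 1 to compound 4 (within the scatter). At this position, then, the added oxygen leaves the read-out unchanged within the scatter, and the number stays near the bottom of the series. No measurement at hand explains this result. As far as these compounds go, whether an amine or a carboxylic acid on this same carbon would change the number remains open. Also open, from the compounds shown here alone, is which features lift compound 2 and compound 3, as each differs from compound 1 in more than one place.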